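A few compounds are considered here, and "the series" means these few. Any claim that something is new, unique, unknown or untested is made for them only; others in the source may bear on it.

Among the compounds with values here, compound 2 `O=S(=O)(c1cccc(Cl)c1)n1ccc2c(N3CCNCC3)cccc21` gives 0.251 nM in an assay on HeLa cells for displacement of a labelled ligand from 5-hydroxytryptamine receptor 6 (Homo sapiens) (on this read-out higher numbers stand for weaker inhibition and lower numbers for stronger inhibition), the lowest of the three numbers so far. Compound 1 `O=S(=O)(c1ccccc1Cl)n1ccc2c(N3CCNCC3)cccc21` gives 0.398 nM, and a 1.6-fold lower number from compound 1 to compound 2 (0.20 log units; within the scatter) stays within the scatter, so these two are not separated. Compound 3 `O=S(=O)(c1ccccn1)n1ccc2c(N3CCNCC3)cccc21` gives 1 nM; a 4.0-fold higher number from compound 2 to compound 3 (0.60 log units; beyond the scatter) and a 2.5-fold higher number from compound 1 to compound 3 (0.40 log units; beyond the scatter) are modest and beyond the scatter. Compound 4 `O=S(=O)(c1cccc(Cl)c1)n1ccc2c(N3CCNCC3)ccc(Cl)c21` keeps the sulfonyl aryl of compound 2 and differs from it in one place: chloro in place of hydrogen on an aromatic carbon. Within the data shown here, all three measured steps change the aryl group on the sulfonyl sulfur and none touches the shared core, so no measured step bears on this change directly. With nothing to indicate a direction, the expectation for compound 4 is a number close to that of compound 2, and a 1.2-fold higher number from compound 2 to compound 4 (0.08 log units; within the scatter) is expected to stay within the scatter. For compound 4 the estimate is 0.3 nM, with a range from 0.1 nM to 1 nM kept wide since the change is of an untested kind.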

Compound 4, inhibition constant: 0.316 nM
Compound 4: the middle estimate sits 1.1-fold (0.02 log units) below what was measured; measured number inside the range.
By their numbers in this assay, from the lowest: compounds 2, 4 and 1 (each within the scatter of the next); then compound 3.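

In this assay, chloro in place of hydrogen on the aromatic carbon para to a piperazin-1-yl group gives a 1.3-fold higher number from compound 2 to compound 4 (0.10 log units; within the scatter) and leaves compound 2 and compound 4 unseparated. Within the data shown here, this is the first measured step on the shared core rather than on the aryl group on the sulfonyl sulfur, and with the 3-chlorophenyl group held fixed, a chloro group at this position leaves the number within the scatter. Nothing available explains this result.

As far as these compounds go, whether other groups at this position, such as methoxy, an amine or a carboxylic acid, would also stay within the scatter remains open. Also open, from the compounds shown here alone, is whether chloro here would give the same result with 2-chlorophenyl or pyridin-2-yl on the sulfonyl sulfur.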